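Swapping methoxy for isobutyl in compound 2

A few compounds are considered here, and "the series" means these few. Any claim that something is new, unique, unknown or untested is made for them only; others in the source may bear on it.

Measured in a functional assay on HT-29 cells (Homo sapiens) for antiproliferative activity, read by sulforhodamine B assay, with a stated time of 48 h; a lower number here means a stronger inhibitor, a higher number a weaker inhibitor:
- Compound 1 `O=C1NCCN1c1ccc(S(=O)(=O)Nc2ccc(F)cc2)cc1`: 370 nM
- Compound 2 `COc1ccc(NS(=O)(=O)c2ccc(N3CCNC3=O)cc2)cc1`: 800 nM

Compound 2 has the higher of the two numbers, so it is the weaker inhibitor. Compound 3 `CC(C)Cc1ccc(NS(=O)(=O)c2ccc(N3CCNC3=O)cc2)cc1` differs from it in one place: isobutyl in place of methoxy on an aromatic carbon. Among the measured compounds shown here, only one measured step bears on this place: a 2.2-fold higher number from compound 1 to compound 2 (0.33 log units; beyond the scatter). That modest step involves neither isobutyl nor the same swap, so it is a rough guide. A small rise in this assay is expected, possibly within the scatter. The estimated step is a 1.3-fold higher number from compound 2 to compound 3 (0.10 log units; within the scatter). The expected value for compound 3 is 1000 nM, within an estimated range of 300 nM to 3500 nM.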

Compound 3, half-maximal inhibitory concentration: > 1000 nM
Compound 3 was reported as a limit; the forecaster's own chance of this, stated with the estimate: 5%; the middle value sits exactly at the limit.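

In this assay, compound 3 is reported as a limit and not as a number: the limit of > 1000 nM in this assay, at which 1 of the 3 values shown sits.

Against methoxy, the result is an at least 1.2-fold higher number from compound 2 to compound 3 (0.09 log units; that floor lies within the scatter), so this floor alone does not separate isobutyl from methoxy at this position, para to a large group. Against fluoro, the result is an at least 2.7-fold higher number from compound 1 to compound 3 (0.43 log units; beyond the scatter), so isobutyl, like methoxy, gives a weaker inhibitor than fluoro does.

As far as these compounds go, the true number for compound 3 remains open, as does whether chloro or an amine at this position would match fluoro.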